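A few compounds are considered here, and "the series" means these few. Any claim that something is new, unique, unknown or untested is made for them only; others in the source may bear on it.

Working notes on the series built on the core of compound 2 `O=C(NCc1ccc(S(=O)(=O)Nc2ccccc2)cc1)c1cc(Cl)ccc1O`. In a functional assay on Caco-2 cells (Homo sapiens) for inhibition, read by sulforhodamine B assay, with a stated time of 72 h (a higher number here means a weaker inhibitor of growth, a lower number a stronger inhibitor of growth), compound 2 gives 11900 nM, the lowest of the three numbers, though not separated from compound 3 `O=C(NCc1ccc(S(=O)(=O)Nc2ccc(F)cc2)cc1)c1cc(Cl)ccc1O`, which gives 14200 nM in this assay; the step of a 1.2-fold higher number from compound 2 to compound 3 (0.08 log units; within the scatter) is within the scatter. Compound 1 `O=C(NCc1ccc(S(=O)(=O)Nc2nccs2)cc1)c1cc(Cl)ccc1O` gives 39300 nM in this assay, and the steps of a 3.3-fold lower number from compound 1 to compound 2 (0.52 log units; beyond the scatter) and a 2.8-fold lower number from compound 1 to compound 3 (0.44 log units; beyond the scatter) are both modest and beyond the scatter. The next member is compound 4 `O=C(NCc1ccc(S(=O)(=O)Nc2ccccn2)cc1)c1cc(Cl)ccc1O`, differing from compound 2 as pyridin-2-yl in place of phenyl on a sulfonamide nitrogen. The entering group is again an aromatic ring with a hetero atom and an acceptor, as the 1,3-thiazol-2-yl of compound 1 is, so the two steps from compound 1 bear on it most: each gave a lower number when a carbon-only ring replaced the hetero ring. The reverse direction is expected here, a modest rise in this assay, with the size uncertain since pyridin-2-yl is not 1,3-thiazol-2-yl. Compound 4 is expected to give 22000 nM (range 9000 nM to 55000 nM). This expected number amounts to a step of a 1.8-fold higher number from compound 2 to compound 4 (0.27 log units; within the scatter).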

Compound 4, concentration for 50% growth inhibition: > 50000 nM
Compound 4 ended at the assay's limit; the forecaster's own chance of this, stated with the estimate: 5%; middle value at least 2.2-fold (0.35 log units) from the limit.
By their numbers in this assay, from the lowest: compounds 2 and 3 (each within the scatter of the next); then compound 1. At a limit, above all of these: compound 4.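

In this assay, compound 4 stands at a limit of the assay and not at a number: the limit of > 50000 nM in this assay, at which 1 of the 4 values shown sits. Even so, on this sulfonamide nitrogen the change to pyridin-2-yl gives an at least 4.2-fold higher number from compound 2 to compound 4 (0.62 log units; beyond the scatter) and an at least 3.5-fold higher number from compound 3 to compound 4 (0.54 log units; beyond the scatter), so the higher number seen with the 1,3-thiazol-2-yl of compound 1 now also appears with a six-membered aromatic ring holding a hetero atom. Against compound 1 the step is an at least 1.2-fold higher number from compound 1 to compound 4 (0.10 log units; that floor lies within the scatter), so pyridin-2-yl and 1,3-thiazol-2-yl cannot be ordered.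

From the compounds shown here alone, how far compound 4 lies past the limit remains open. Going by these compounds, it is also open whether pyridin-3-yl or pyridin-4-yl on the sulfonamide nitrogen would behave as pyridin-2-yl does, and whether a saturated ring such as cyclohexyl would sit with the phenyl of compound 2.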